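Swapping the Aryl Group on a Weak Cell-Growth Inhibitor

The source may report more compounds than this note shows. Statements on the series, on what has been measured and on what is new or still open speak of the compounds shown alone.

Compound 1 `O=C1C(Nc2ccc(I)cc2)=CC(=O)c2c1nc1n2[C@H]2OC[C@@H](O)[C@H]2OC1` and compound 2 `O=C1C=C(Nc2ccc(C(F)(F)F)cc2)C(=O)c2c1nc1n2[C@H]2OC[C@@H](O)[C@H]2OC1` share one core and differ only in the group on the amine nitrogen. In a functional assay on HeLa cells (Homo sapiens) for inhibition, read by sulforhodamine B assay (a lower number here means a stronger inhibitor, a higher number a weaker inhibitor), compound 1 gives 4010 nM. For compound 2 this assay reports only a limit, > 8000 nM, so no number is known; this is the limit of > 8000 nM in this assay, at which 1 of the 2 values shown sits. Compound 3 `O=C1C=C(Nc2cccc(Cl)c2)C(=O)c2c1nc1n2[C@H]2OC[C@@H](O)[C@H]2OC1` carries 3-chlorophenyl in place of 4-(trifluoromethyl)phenyl on an amine nitrogen. Among the measured compounds shown here, no measured pair shows how such a change acts here, so the step expected is an at least 1.1-fold lower number from compound 2 to compound 3 (0.05 log units; that floor lies within the scatter), probably not beyond the scatter. Compound 3 is therefore estimated at 7000 nM, between 2500 nM and 20000 nM.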

Compound 3, half-maximal inhibitory concentration: 6040 nM
The estimate for compound 3 lay 1.2-fold (0.06 log units) above the measured number, and the stated range covers the measured number.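

In this assay, among the compounds shown here, compound 3, with 3-chlorophenyl on the amine nitrogen, gives a real number, which makes this the first measured value for this arrangement of the shared core. Replacing 4-(trifluoromethyl)phenyl with 3-chlorophenyl gives an at least 1.3-fold lower number from compound 2 to compound 3 (0.12 log units; that floor lies within the scatter). That step has only a floor, and its true size remains unknown, because compound 2 has only a limit: the limit of > 8000 nM in this assay, at which 1 of the 3 values shown sits.

This single swap changes both the substituent and its numbered place on the phenyl ring, so the two contributions cannot be separated. On these data alone, how an amine or a carboxylic acid in place of the chlorine would read remains open.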